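The source may hold more compounds than are shown below. What is called first, only, known or untested is meant among the compounds shown, and "the series" means these compounds.

Three compounds have numbers in an assay on RPMI-8226 cells for antagonist activity at P2X purinoceptor 7 (Homo sapiens), read by calcium flux; on this read-out higher numbers stand for weaker inhibition and lower numbers for stronger inhibition. Compound 1, `O=c1[nH]c2ccccc2n1CCCN1CCC(C(O)(c2ccccc2)c2ccccc2)CC1`, gives 7500 nM in this assay. Compound 2, `O=c1[nH]c2ccccc2n1CCCN1CCC(=C(c2ccccc2)c2ccccc2)CC1`, gives 2400 nM. Compound 3, `Cc1nc2ccccc2n1CCCCN1CCN(C(c2ccccc2)c2ccccc2)CC1`, gives 850 nM, the lowest of the three numbers; compound 2 stands nearest to it and compound 1 furthest, and both gaps lie beyond the usual scatter. Compound 4, `Fc1ccc2c(ccn2CCCCN2CCN(C(c3ccccc3)c3ccccc3)CC2)c1`, has not yet been measured in this assay. It differs from compound 3 in one place: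

5-fluoro-1H-indol-1-yl in place of 2-methyl-1H-benzimidazol-1-yl on a saturated chain carbon, four bonds along the chain from an amine nitrogen in a ring

No pair of measured compounds shows a change of this kind, so its size cannot be read from the numbers shown. In this assay the step from compound 3 to compound 4 is expected to be small, a 1.4-fold higher number from compound 3 to compound 4 (0.15 log units; within the scatter), at most a slight move toward a higher number and possibly none beyond the scatter. Compound 4 is therefore estimated at 1200 nM in this assay, with a likely range from 350 nM to 4000 nM.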

Compound 4, half-maximal inhibitory concentration: 120 nM
For compound 4 the middle estimate is 10-fold (1.00 log units) above the measured one; the whole stated range lies above it.
By their numbers in this assay, from the lowest: compound 4; then compound 3; then compound 2; then compound 1.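

In this assay, putting 5-fluoro-1H-indol-1-yl in place of 2-methyl-1H-benzimidazol-1-yl on a saturated chain carbon, four bonds along the chain from an amine nitrogen in a ring, gives a 7.1-fold lower number from compound 3 to compound 4 (0.85 log units; beyond the scatter). Within the data shown here, this is the first one-place comparison, and it shows that the number responds clearly to the group at this position, even though both groups have the same count of heavy atoms. No measurement shown here accounts for the size of this step.

As far as these compounds go, the exchange changes several things at once: the methyl group leaves, a ring nitrogen gives way to carbon, and fluorine enters, so the share of each remains open. The unsubstituted 1H-indol-1-yl group would separate the contribution of the fluorine from that of the rest of the exchange.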